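Pyrrolidine in Place of Ethylamine on Two Cores

The source may report more compounds than this note shows. Statements on the series, on what has been measured and on what is new or still open speak of the compounds shown alone.

Measured so far in a functional assay on MCF7 cells (Homo sapiens) for inhibition; a higher number here means a weaker inhibitor, a lower number a stronger inhibitor:
compound 1 `CCN(C(=O)CC(CC(=O)NCCN1CCCC1)c1ccc(Cl)cc1)C1Cc2ccccc2C1` gives 20400 nM.
compound 2 `CCNCCNC(=O)CC(CC(=O)N(CC)C1Cc2ccccc2C1)c1ccc(Cl)cc1` gives 14400 nM.
compound 3 `CCNCCNC(=O)CC(CC(=O)N(CC)C1Cc2ccccc2C1)c1ccccc1` gives > 100000 nM, which is a limit of the assay and not a number.

Compound 2 and compound 3 differ in their core: hydrogen in place of chloro on an aromatic carbon. That step, an at least 6.9-fold higher number from compound 2 to compound 3 (0.84 log units; beyond the scatter), carries compound 3 to the limit of > 100000 nM in this assay, at which 1 of the 3 values shown sits. The change from compound 2 to compound 1 is pyrrolidin-1-yl in place of ethylamino on a saturated chain carbon, two bonds along the chain from an amide-type nitrogen, and it made a 1.4-fold higher number from compound 2 to compound 1 (0.15 log units; within the scatter). Compound 4 `CCN(C(=O)CC(CC(=O)NCCN1CCCC1)c1ccccc1)C1Cc2ccccc2C1`, not yet measured, carries the same change on the core of compound 3: pyrrolidin-1-yl in place of ethylamino on a saturated chain carbon, two bonds along the chain from an amide-type nitrogen. The step from compound 3 to compound 4 is expected to be a step that the limit leaves unreadable from compound 3 to compound 4 because the earlier step of a 1.4-fold higher number from compound 2 to compound 1 (0.15 log units; within the scatter) lay within the scatter. Compound 4 is therefore estimated at 150000 nM, most likely again reported only as a limit, with a range from 50000 nM to 500000 nM.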

Compound 4, half-maximal inhibitory concentration: > 100000 nM
Compound 4: no number, only a limit; the forecaster's own chance of this, stated with the estimate: 80%; the middle value does not contradict the limit.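

In this assay compound 4 gives > 100000 nM, which is a limit of the assay and not a number. Hydrogen in place of chloro gives an at least 4.9-fold higher number from compound 1 to compound 4 (0.69 log units; beyond the scatter), so the weakening seen with the ethylamino group also appears with the pyrrolidin-1-yl group, but the two steps cannot be compared exactly: the same change on two cores in this assay, an at least 6.9-fold higher number (0.84 log units; beyond the scatter) from compound 2 to compound 3 and an at least 4.9-fold higher number (0.69 log units; beyond the scatter) from compound 1 to compound 4; the limit leaves it open whether they differ The step from ethylamino to pyrrolidin-1-yl cannot be read on the core of compound 3, so it remains unknown whether the result for that change carries over from the core of compound 1: the limit of > 100000 nM in this assay, at which 2 of the 4 values shown sit.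

The compounds shown leave open whether a fluoro or a methoxy group could take the place of chloro. They also leave open how a piperidine or a dimethylamino group would compare with pyrrolidin-1-yl.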